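Carboxamide series: from methylcarbamoyl to 2-(methylcarbamoyl)ethenyl

The source may report more compounds than this note shows. Statements on the series, on what has been measured and on what is new or still open speak of the compounds shown alone.

Measured compounds:
compound 1 `O=C(c1c(O)ccc2cc(-c3cccc(O)c3)ccc12)N1CCCCC1`: 29%
compound 2 `CNC(=O)c1c(O)ccc2cc(-c3cccc(O)c3)ccc12`: 22%

In an in vitro assay on Sf9 cells for inhibition of 17-beta-hydroxysteroid dehydrogenase type 1 (Homo sapiens), tested at 100 nM (on this read-out higher numbers stand for a stronger effect at the one concentration tested and lower numbers for a weaker effect), compound 1 gives 29%, and compound 2 gives 22%. For the measured compounds named here, the only measured step, a number 7 percentage points lower from compound 1 to compound 2 (within the scatter), lies within the scatter. Compound 2 thus stands lowest of the two numbers, with compound 1 as its nearest neighbour inside the scatter, so no order between the two can be read.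

Compound 3 `CNC(=O)/C=C/c1c(O)ccc2cc(-c3cccc(O)c3)ccc12` differs from compound 2 as follows: 2-(methylcarbamoyl)ethenyl in place of methylcarbamoyl on an aromatic carbon. Going by the values given here, the one measured step, a number 7 percentage points lower from compound 1 to compound 2 (within the scatter), alters the amine part on the carbonyl and leaves the link to the ring untouched; it does not bear on the insertion of an ethenyl unit. Without any step of this kind, no shift beyond the scatter is expected in this assay, but the range must be wide. Compound 3 is estimated at 22%, between 5% and 45%. The estimated step is no change at the digits printed from compound 2 to compound 3 (within the scatter).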

Compound 3, a percentage reported as inhibition, at one concentration (the size of the read-out at that concentration, not a potency): 19%
Estimate against measurement, compound 3: 3 percentage points above; the range from low to high includes it.
By their numbers in this assay, from the lowest: compounds 3, 2 and 1 (each within the scatter of the next).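

Working notes on the position ortho to a hydroxy group: in this assay, 2-(methylcarbamoyl)ethenyl in place of methylcarbamoyl gives a number 3 percentage points lower from compound 2 to compound 3 (within the scatter) and so shows that the larger group with its extra double bond outside aromatic rings can sit on this aromatic carbon with no step beyond the scatter. Set against the piperidine amide, the same group gives a number 10 percentage points lower from compound 1 to compound 3 (within the scatter), so all three groups at this carbon remain within the scatter of one another at the one concentration tested. No supporting data bear on why these values stay so close.

Going by these compounds, whether a carboxylic acid, an amine or a longer chain on this aromatic carbon would give a step beyond the scatter remains open. Also open, on these data alone, is what piperidin-1-yl on the carbonyl of the ethenyl group would give.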